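Swapping the Iodo Ring for a Methoxy Ring

The source may hold more compounds than are shown below. What is called first, only, known or untested is meant among the compounds shown, and "the series" means these compounds.

Compound 3 `C=C(Br)C(=O)Nc1ccc(/C=C/C(=O)c2ccc(I)cc2)cc1` stands at the high end of three measurements in a functional assay on HeLa cells (Homo sapiens) for antiproliferative activity, with a stated time of 48 h; a higher number here means a weaker inhibitor, a lower number a stronger inhibitor: compound 3 gives 7700 nM, whereas compound 1 `C=C(Br)C(=O)Nc1ccc(/C=C/C(=O)c2ccc(F)cc2)cc1` gives 1400 nM and compound 2 `C=C(Br)C(=O)Nc1ccc(/C=C/C(=O)c2ccc(Cl)cc2)cc1` gives 1600 nM. The steps of a 5.5-fold higher number from compound 1 to compound 3 (0.74 log units; beyond the scatter) and a 4.8-fold higher number from compound 2 to compound 3 (0.68 log units; beyond the scatter) mark compound 3 as the weakest of the three, while a 1.1-fold higher number from compound 1 to compound 2 (0.06 log units; within the scatter) lies within the scatter. Compound 4 `C=C(Br)C(=O)Nc1ccc(/C=C/C(=O)c2cccc(OC)c2)cc1` alters the ring on the carbonyl carbon: 3-methoxyphenyl in place of 4-iodophenyl on a carbonyl carbon. Among the compounds with values here, no measured step exchanges a halogen for a methoxy group, so the only guide is that the iodo ring gave the highest number and a move away from it may bring the number back toward those of compounds 1 and 2. For compound 4 the expected step is a 3.1-fold lower number from compound 3 to compound 4 (0.49 log units; beyond the scatter). Compound 4 is therefore estimated at 2500 nM, with a range from 800 nM to 8000 nM.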

Compound 4, half-maximal inhibitory concentration: 700 nM
Compound 4: middle estimate off by 3.6-fold (0.55 log units), on the high side, outside the stated range (below it).
By their numbers in this assay, from the lowest: compounds 4, 1 and 2 (each within the scatter of the next, the first and the last beyond it); then compound 3.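

The ring on the carbonyl carbon need not carry a halogen: 3-methoxyphenyl, which adds a hydrogen-bond acceptor, gives an 11-fold lower number from compound 3 to compound 4 (1.04 log units; beyond the scatter) and also a 2.3-fold lower number from compound 2 to compound 4 (0.36 log units; beyond the scatter). Against the fluoro ring there is a 2.0-fold lower number from compound 1 to compound 4 (0.30 log units; within the scatter), so compound 4 and compound 1 cannot be ranked. No measurement available here explains these differences. Because group and ring position change together, the compounds shown leave open what the methoxy group contributes by itself. From the compounds shown here alone, how an amine or a carboxylic acid would fare on this ring also remains open.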